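A Five-Membered Sulfur Ring Replaces 2-Chloroethenyl

The compounds below may be only part of what the source reports. "The series", "measured", "known", "first", "only" and "open" are said of these compounds alone.

In an ADME assay on L1210/0 cells (Mus musculus) for cytotoxicity, with a stated time of 48 h (on this read-out higher numbers stand for weaker inhibition and lower numbers for stronger inhibition), compound 1 `C=C(Cl)c1cn([C@H]2C[C@H](O)[C@@H](CO)O2)c(=O)[nH]c1=O` gives 1660 nM. Compound 2 `O=c1[nH]c(=O)n([C@H]2C[C@H](O)[C@@H](CO)O2)cc1/C=C/Cl` gives > 200000 nM, which is a limit of the assay and not a number. For the measured compounds named here, the one measured step, an at least 120-fold higher number from compound 1 to compound 2 (2.08 log units; beyond the scatter), comes with 2-chloroethenyl in place of 1-chloroethenyl on an aromatic carbon, so the group at this carbon can matter greatly here. Compound 3 `O=c1[nH]c(=O)n([C@H]2C[C@H](O)[C@@H](CO)O2)cc1C1SCCS1` keeps the core of compound 2 and changes that same group: a group of 5 heavy atoms (3 carbon, 2 sulfur; one five-membered non-aromatic ring with 2 hetero atoms) in place of a group of 3 heavy atoms (2 carbon, 1 chlorine; no ring), on an aromatic carbon. The step from compound 1 is a different swap and gives only loose guidance, but it shows that compound 2 starts from the weak end of the scale. No large gain is expected from this new group, and the expected change is an at least 1.3-fold lower number from compound 2 to compound 3 (0.12 log units; that floor lies within the scatter). For compound 3 the estimated value is 150000 nM, with an expected range of 30000 nM to 300000 nM.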

Compound 3, half-maximal inhibitory concentration: > 200000 nM
Compound 3: no number, only a limit (the forecaster's own chance of this, stated with the estimate: 60%); middle value at least 1.3-fold (0.12 log units) from the limit.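

Set against the 1-chloroethenyl group of compound 1, the five-membered ring with two sulfur atoms gives an at least 120-fold higher number from compound 1 to compound 3 (2.08 log units; beyond the scatter). A second, very different group on this aromatic carbon therefore also ends far on the weak side, so the weak result is not confined to the 2-chloroethenyl group of compound 2. The change from compound 2 to compound 3 cannot be read, and neither group can be ranked over the other, because both compounds stop at the same limit of the assay: the limit of > 200000 nM in this assay, at which 2 of the 3 values shown sit.

Still open, from the compounds shown here alone, is how much weaker compound 2 and compound 3 really are, since a limit gives no number. Going by these compounds, it is also open whether strength at this carbon needs the 1-chloroethenyl group itself, which a plain ethenyl group, a 1-bromoethenyl group or an amine there could help to test.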